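The source may report more compounds than this note shows. Statements on the series, on what has been measured and on what is new or still open speak of the compounds shown alone.

Within the data shown here, compound 2 `CCCCCOC(=O)N1CCN(C(=O)c2nc(Nc3cc(C4CC4)[nH]n3)c3cc(Cl)ccc3n2)C[C@H]1C` stands at the lower end of the two numbers so far in an ADME assay on a cell-free system (plasma, Homo sapiens), read by HPLC, with a stated time of 120 min, at 37 degrees C; on this read-out higher numbers stand for a more stable compound and lower numbers for a less stable compound: compound 2 gives 74.4%, while compound 1 `C[C@@H]1CN(C(=O)c2nc(Nc3cc(C4CC4)[nH]n3)c3cc(Cl)ccc3n2)CCN1C(=O)OCc1ccccc1` gives 86.2%. Among the measured compounds shown here, the only measured step, a number 11.8 percentage points lower from compound 1 to compound 2 (beyond the scatter), is the one known comparison.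

Compound 3 `CC(OC(=O)C(C)C)OC(=O)N1CCN(C(=O)c2nc(Nc3cc(C4CC4)[nH]n3)c3cc(Cl)ccc3n2)C[C@H]1C` differs from compound 2 in that (1-((isopropylcarbonyl)oxy)ethyl in place of pentyl on an oxygen next to a carbonyl group). For the measured compounds named here, the measured step bears on it only loosely: it swapped a phenyl for a butyl on the same kind of position and cost a modest amount, whereas the entering group here brings in an additional ester link that no measured pair covers. Going by the values given here, no measured step therefore sets the size of this change. As an expectation only, compound 3 is estimated at 45% in this assay, a step of a number 29.4 percentage points lower from compound 2 to compound 3 (beyond the scatter), with a wide range from 10% to 80%.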

Compound 3, percent of the compound remaining: 17.4%
The estimate for compound 3 lay 27.6 percentage points above the measured number; the range from low to high includes it.
By their numbers in this assay, from the lowest: compound 3; then compound 2; then compound 1.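

The group on the oxygen next to a carbonyl group can matter far more than the first pair suggested: in this assay, 1-((isopropylcarbonyl)oxy)ethyl in place of pentyl gives a number 57 percentage points lower from compound 2 to compound 3 (beyond the scatter), and the same group in place of benzyl gives a number 68.8 percentage points lower from compound 1 to compound 3 (beyond the scatter). Both steps are large, whereas the earlier change between the two simple carbamate side groups was modest, so this position does not tolerate every group equally. Nothing measured here explains why compound 3 stands so low.

The compounds shown leave open which part of the entering group carries the change, a question that a plain ethyl or a 1-(acetyloxy)ethyl on the same oxygen could help to address. Also open, going by these compounds, is what compound 3 turns into, as the read-out follows only the compound remaining.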